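Swapping a Pyridyl Substituent on Two Related Cores

The source may report more compounds than this note shows. Statements on the series, on what has been measured and on what is new or still open speak of the compounds shown alone.

Compound 1 `CC(=O)Nc1ccc(-c2ccc(C(=O)N[C@H]3CN[C@@H](C(=O)Nc4ccc(Cl)c(C(F)(F)F)c4)C3)cc2)cn1` and compound 2 `O=C(NC1CC1)c1cncc(-c2ccc(C(=O)N[C@H]3CN[C@@H](C(=O)Nc4ccc(Cl)c(C(F)(F)F)c4)C3)cc2)c1` share one core; in a functional assay on K562 cells (Homo sapiens) for inhibition, read by MTT assay, with a stated time of 48 h (on this read-out higher numbers stand for weaker inhibition and lower numbers for stronger inhibition), compound 1 gives 22800 nM and compound 2 gives 65300 nM. The change between them, (5-(cyclopropylcarbamoyl)pyridin-3-yl in place of 6-acetamidopyridin-3-yl on an aromatic carbon), made a step of a 2.9-fold higher number from compound 1 to compound 2 (0.46 log units; beyond the scatter). Compound 3 `CC(=O)Nc1ccc(-c2ccc(C(=O)N[C@@H](C)C(=O)Nc3ccc(Cl)c(C(F)(F)F)c3)cc2)cn1` is built on a different core, and how the two cores differ is not broken down here. In this assay compound 3 gives 107000 nM. Compound 4 `C[C@H](NC(=O)c1ccc(-c2cncc(C(=O)NC3CC3)c2)cc1)C(=O)Nc1ccc(Cl)c(C(F)(F)F)c1` has not yet been measured; it carries the same change against compound 3, (5-(cyclopropylcarbamoyl)pyridin-3-yl in place of 6-acetamidopyridin-3-yl on an aromatic carbon). Among these compounds the change occurs only twice, so the expectation rests on a single measured pair. Compound 4 is expected to show a step of a 2.6-fold higher number from compound 3 to compound 4 (0.42 log units; beyond the scatter) in this assay, because the same change gave a 2.9-fold higher number from compound 1 to compound 2 (0.46 log units; beyond the scatter). Compound 4 is therefore estimated at 280000 nM, with a likely range from 130000 nM to 600000 nM.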

Compound 4, half-maximal inhibitory concentration: 396000 nM
For compound 4 the middle estimate is 1.4-fold (0.15 log units) below the measured one; low and high end bracket the measured number.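

In this assay the swap raises the number again, with a 3.7-fold higher number from compound 3 to compound 4 (0.57 log units; beyond the scatter). The change therefore carried over from the core of compound 1 to the core of compound 3 with a similar step size: the same change on two cores in this assay, a 2.9-fold higher number (0.46 log units; beyond the scatter) from compound 1 to compound 2 and a 3.7-fold higher number (0.57 log units; beyond the scatter) from compound 3 to compound 4, 1.3-fold (0.11 log units) apart, within the scatter of two such steps. Among the compounds shown here, with only two pairs, this shows agreement on these two cores, but it cannot show that the step would hold on a third core, and it does not explain why the number rises.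

The compounds shown leave open what would happen if a pyridine ring carrying an amine or a carboxylic acid entered at the same place. They also leave open whether the step would hold in any assay other than this assay.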